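Working notes: removing the ring-nitrogen 4-fluorophenyl in this series

A few compounds are considered here, and "the series" means these few. Any claim that something is new, unique, unknown or untested is made for them only; others in the source may bear on it.

Measured in a functional assay on HCT-116 cells (Homo sapiens) for antiproliferative activity, read by MTT assay, with a stated time of 72 h; a higher number here means a weaker inhibitor, a lower number a stronger inhibitor:
- compound 1 `O=C1COc2ccc(-c3cnc(Cl)c(NS(=O)(=O)c4ccc(F)cc4)c3)cc2N1c1ccc(F)cc1` gives 34200 nM.
- compound 2 `O=C1COc2ccc(-c3cnc(Cl)c(NS(=O)(=O)c4ccc(F)cc4)c3)cc2N1` reaches only the assay limit, > 40000 nM.
- compound 3 `O=C1COc2ccc(-c3cnc4ccccc4c3)cc2N1c1ccc(F)cc1` likewise reaches only the assay limit, > 40000 nM.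

Compound 1 and compound 2 differ by hydrogen in place of 4-fluorophenyl on an amide-type nitrogen in a ring. The measured step is an at least 1.1-fold higher number from compound 1 to compound 2 (0.06 log units; that floor lies within the scatter); its floor rests on (the limit of > 40000 nM in this assay, at which 2 of the 3 values shown sit). Compound 4 `O=C1COc2ccc(-c3cnc4ccccc4c3)cc2N1`, not yet measured, differs from compound 3 by hydrogen in place of 4-fluorophenyl on an amide-type nitrogen in a ring, the same change at a place described in the same words. How the core of compound 3 differs from the core of compound 1 is not broken down here.

For compound 4 in this assay the expected step is a step that the limit leaves unreadable from compound 3 to compound 4, resting on an at least 1.1-fold higher number from compound 1 to compound 2 (0.06 log units; that floor lies within the scatter), which pointed towards a weaker inhibitor. Compound 4 is estimated at 60000 nM, between 30000 nM and 150000 nM, and is expected to be reported most likely only as a limit.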

Compound 4, half-maximal inhibitory concentration: > 40000 nM
Compound 4: a limit, no number (the forecaster's own chance of this, stated with the estimate: 85%); the middle value does not contradict the limit.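

Compound 3 and compound 4 both sit at a limit, so no step between them can be read: the limit of > 40000 nM in this assay, at which 3 of the 4 values shown sit.

From the compounds shown here alone, whether hydrogen in place of 4-fluorophenyl changes activity at all, on either core, remains open.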